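Trimming One Chloro from a Pyridinyl Sulfonamide

A few compounds are considered here, and "the series" means these few. Any claim that something is new, unique, unknown or untested is made for them only; others in the source may bear on it.

compound 1: `O=S(=O)(O)CSc1nnc(Br)n1Cc1ccc(Br)c2ccccc12` with 14400 nM
compound 2: `O=S(=O)(CSc1nnc(Br)n1Cc1ccc(Br)c2ccccc12)Nc1ccc(Cl)nc1Cl` with 1660 nM

In an assay on HEK293 cells for inhibition of solute carrier family 22 member 12 (Homo sapiens) (a lower number here means a stronger inhibitor, a higher number a weaker inhibitor), compound 1 gives 14400 nM and compound 2 gives 1660 nM. Compound 2 therefore has the lowest number of the two, reached through the step of an 8.7-fold lower number from compound 1 to compound 2 (0.94 log units; beyond the scatter). Compound 3 `O=S(=O)(CSc1nnc(Br)n1Cc1ccc(Br)c2ccccc12)Nc1cccnc1Cl` keeps that sulfonamide and differs from compound 2 only in that (hydrogen in place of chloro on an aromatic carbon). Going by the values given here, no measured step touches this part of the molecule, so the one known step offers no direct guide. Compound 3 is expected to stay close to compound 2, with a step of a 1.5-fold higher number from compound 2 to compound 3 (0.18 log units; within the scatter), and is estimated at 2500 nM (range 900 nM to 7000 nM).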

Compound 3, half-maximal inhibitory concentration: 5100 nM
For compound 3 the middle estimate is 2.0-fold (0.31 log units) below the measured one; low and high end bracket the measured number.
By their numbers in this assay, from the lowest: compound 2; then compound 3; then compound 1.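

Hydrogen in place of the chloro next to the ring nitrogen gives a 3.1-fold higher number from compound 2 to compound 3 (0.49 log units; beyond the scatter), so this single heavy atom counts for something in this series. With only the remaining chloro, (2-chloropyridin-3-yl)amino in place of hydroxy still gives a 2.8-fold lower number from compound 1 to compound 3 (0.45 log units; beyond the scatter), which means a real part of the gain from the sulfonamide survives without the lost chloro. No measurement here bears on the reason for this difference.

From the compounds shown here alone, whether fluoro or methyl at the same place could match chloro stays open. So does the contribution of the remaining chloro.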